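One More Methoxy on a Shared Core

The compounds below may be only part of what the source reports. "The series", "measured", "known", "first", "only" and "open" are said of these compounds alone.

Compound 1: `COc1ccc(-c2cc(/C=C/C(=O)c3cc(OC)c(OC)c(OC)c3)[nH]n2)cc1OC` gives 93%
Compound 2: `COc1ccc(C(=O)/C=C/c2cc(-c3cc(OC)c(OC)c(OC)c3)n[nH]2)cc1OC` gives 100%

Of the compounds shown here, two have so far been measured in a functional assay on SR cells (Homo sapiens) for cytotoxicity, read by sulforhodamine B assay, with a stated time of 48 h, tested at 0.01 uM; a higher number here means a weaker effect of the compound at the concentration tested, a lower number a stronger effect. Compound 1, `COc1ccc(-c2cc(/C=C/C(=O)c3cc(OC)c(OC)c(OC)c3)[nH]n2)cc1OC`, gives 93%, and compound 2, `COc1ccc(C(=O)/C=C/c2cc(-c3cc(OC)c(OC)c(OC)c3)n[nH]2)cc1OC`, gives 100%. The two values lie within the scatter of each other, so neither compound can be set above the other on this read-out; both leave most of the cells untouched at the concentration tested. Compound 2 is the one carried forward here.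

Compound 3, `COc1cc(C(=O)/C=C/c2cc(-c3cc(OC)c(OC)c(OC)c3)n[nH]2)cc(OC)c1OC`, has not yet been measured. It differs from compound 2 in one place: methoxy in place of hydrogen on an aromatic carbon. Among the compounds with values here, with only two measured compounds, both sitting near the top of the scale and within the scatter of each other, there is no measured step to lean on, and nothing in the two values points one way or the other. The step from compound 2 to compound 3 is therefore expected to stay within the scatter, with no clear direction, as a number 5 percentage points lower from compound 2 to compound 3 (within the scatter). Compound 3 is expected to give about 95%, within a range from 80% to 105%.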

Compound 3, a percentage reported as activity, at one concentration (the size of the read-out at that concentration, not a potency): 111%
Compound 3: middle estimate off by 16 percentage points, on the low side; the whole stated range lies below it.
By their numbers in this assay, from the lowest: compounds 1 and 2 (each within the scatter of the next); then compound 3.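

In this assay, methoxy in place of hydrogen on an aromatic carbon, ortho to a methoxy group and meta to a large group, gives the first differences in this set that lie beyond the scatter: a number 11 percentage points higher from compound 2 to compound 3 (beyond the scatter), and a number 18 percentage points higher from compound 1 to compound 3 (beyond the scatter), with both steps modest. At this position, the change therefore moves the read-out towards a weaker effect from either of the two starting compounds, even though those two could not be told apart, and compound 3 shows the weakest effect of the three at the concentration tested. Nothing measured here accounts for this shift.

The compounds shown leave open whether the shift belongs to methoxy itself or would also follow from another group at this position, such as a hydroxyl, an amine or a carboxylic acid. As far as these compounds go, because all three compounds are compared at a single concentration, at which none shows a clear effect on the cells, it also remains open whether the same difference would hold at concentrations where the cells respond more strongly.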